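Replacing tert-butyl with diethylcarbamoyl

A few compounds are considered here, and "the series" means these few. Any claim that something is new, unique, unknown or untested is made for them only; others in the source may bear on it.

Measured so far in an in vitro ADME assay on microsomes from liver (Mus musculus) for pharmacokinetics, read by LC-MS, with a stated time of 10 min, tested at 1 uM; a lower number here means slower removal, a higher number faster removal of the compound:
- compound 1 `CN1C[C@H](C(=O)Nc2ccc(C(F)(F)F)cc2)[C@@H](c2ccc(/C=C/C(=O)Nc3ccccc3N)cc2)C1` gives 23 mL/min/kg
- compound 2 `CC(C)(C)N1C[C@H](C(=O)Nc2ccc(Cl)cc2)[C@@H](c2ccc(/C=C/C(=O)Nc3ccccc3N)cc2)C1` gives 20 mL/min/kg

Compound 2 stands level with compound 1, and the gap between their values lies within the usual scatter of repeated measurements. Compound 3 `CCN(CC)C(=O)N1C[C@H](C(=O)Nc2ccc(Cl)cc2)[C@@H](c2ccc(/C=C/C(=O)Nc3ccccc3N)cc2)C1` carries diethylcarbamoyl in place of tert-butyl on an amine nitrogen in a ring. For the measured compounds named here, no measured pair shows a change of this kind, so the expectation is a loose one. A small rise in this assay is expected, with the estimated step of a 1.4-fold higher number from compound 2 to compound 3 (0.13 log units; within the scatter) probably staying within the scatter. The estimate for compound 3 is 27 mL/min/kg (expected range 13 mL/min/kg to 55 mL/min/kg).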

Compound 3, clearance: 83 mL/min/kg
For compound 3 the middle estimate is 3.1-fold (0.49 log units) below the measured one; measured number outside the range, above it.
By their numbers in this assay, from the lowest: compounds 2 and 1 (each within the scatter of the next); then compound 3.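

In this assay, putting diethylcarbamoyl in place of tert-butyl on the amine nitrogen in the ring gives a 4.2-fold higher number from compound 2 to compound 3 (0.62 log units; beyond the scatter), so removal of the compound responds to what this nitrogen carries. Compound 1 and compound 2 differ in more than one place, so they could not isolate this position. No measurement shown here gives a reason for the rise. Still open, going by these compounds, is which part of diethylcarbamoyl goes with the rise, the carbonyl or the two ethyl groups. An acetyl or a plain ethyl group on the same nitrogen would help separate these.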